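The source may hold more compounds than are shown below. What is called first, only, known or untested is meant among the compounds shown, and "the series" means these compounds.

Measured compounds in an in vitro functional assay on HEK293 cells for antagonist activity at melanin-concentrating hormone receptor 1 (Homo sapiens), read by GTPgammaS binding, with a stated time of 45 min; on this read-out lower numbers stand for stronger inhibition and higher numbers for weaker inhibition:
compound 1, `Cc1ccc(CN2CCC(NC(=O)NCc3ccc(-c4ccc(F)cc4)cc3)CC2)cc1`, gives 198 nM.
compound 2, `Cc1ccc(CN2CCC(NC(=O)NCc3ccc(-c4ccccc4)cc3)CC2)cc1`, gives 1060 nM.
compound 3, `COc1ccc(-c2ccc(CN(CC(=O)C(C)(C)O)C(=O)NC3CCN(Cc4ccc(C)cc4)CC3)cc2)cc1`, gives > 10000 nM, which is a limit of the assay and not a number.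

Within the data shown here, compound 3 thus stands at the limit of > 10000 nM in this assay, at which 1 of the 3 values shown sits; of the three measured compounds it is the only one without a numerical value, while compounds 1 and 2 sit well inside the measured range. Compound 4, `Cc1ccc(CN2CCC(NC(=O)N(CC(=O)C(C)(C)O)Cc3ccc(-c4cccc(C#N)c4)cc3)CC2)cc1`, is the next compound to measure. It differs from compound 3 by 3-cyanophenyl in place of 4-methoxyphenyl on an aromatic carbon.

Among the measured compounds shown here, only one measured step bears on this change: a 5.4-fold higher number from compound 1 to compound 2 (0.73 log units; beyond the scatter). That step also concerns a substituent on an aromatic carbon of a six-membered aromatic ring of carbon only, but it exchanges fluoro for hydrogen rather than 4-methoxyphenyl for 3-cyanophenyl, and compounds 1 and 2 differ from compound 3 elsewhere as well. The step shows that one substituent exchange on such a ring can move the number beyond the scatter; it gives no direction for the present exchange. With compound 3 at the limit, only a move to lower numbers could become visible.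

Compound 4 is expected to remain close to the limit, estimated at 8000 nM (range 1500 nM to 30000 nM). The implied step, an at least 1.2-fold lower number from compound 3 to compound 4 (0.09 log units; that floor lies within the scatter), is an expectation only, and a second limit is the likelier outcome.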

Compound 4, antagonist equilibrium constant: 5000 nM
The estimate for compound 4 lay 1.6-fold (0.20 log units) above the measured number; low and high end bracket the measured number.
By their numbers in this assay, from the lowest: compound 1; then compound 2; then compound 4. At a limit, above all of these: compound 3.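

In this assay, 3-cyanophenyl in place of 4-methoxyphenyl gives an at least 2.0-fold lower number from compound 3 to compound 4 (0.30 log units; that floor lies within the scatter). Compound 3 is held at a limit of the assay and not at a number: the limit of > 10000 nM in this assay, at which 1 of the 4 values shown sits.

The step is therefore a floor only, and the true distance between the two compounds cannot be read from it. What the result adds is that, on the core shared by compound 3 and compound 4, a change at this aromatic carbon, para to a large group, can give a measured number, here 5000 nM for compound 4.

The exchange alters both the substituent on the outer ring, methoxy against nitrile, and its place on that ring, so the compounds shown do not separate these two parts of the change or say which of them carries the step. Also open, as far as these compounds go, is how this position would read with a carboxylic acid, an amine or a longer chain on that ring, and whether the nitrile would give a similar step on the core of compound 1.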